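Replacing the nitrophenyl carbonyl group in compound 1

This account rests on a few compounds, and the source may have more. Where it says the series, first, only, none or still open, it means among the compounds named here.

Compound 1 `Cc1cccc(Cn2c(CN3CCN(C(=O)c4ccc([N+](=O)[O-])cc4)CC3)nc3ccccc32)c1` is the lowest of the three compounds measured in an assay on isolated protein for inhibition of aldehyde dehydrogenase 1A1 (Homo sapiens), read by spectrophotometry, tested at 10 uM (a lower number here means less inhibition, a higher number more inhibition at the concentration tested (going by the name of the read-out)), with compound 1 giving 24.3%. Compound 2 `CC(C)CCn1c(CN2CCN(C(=O)C3CC3)CC2)nc2ccccc21` gives 70% and compound 3 `O=C(C1CC1)N1CCN(Cc2nc3ccccc3n2CC2CCCC2)CC1` gives 44.5%; both carry a cyclopropyl on the carbonyl carbon and differ from each other only at the chain on the aromatic nitrogen, where a number 25.5 percentage points lower from compound 2 to compound 3 (beyond the scatter). Compound 4 `Cc1cccc(Cn2c(CN3CCN(C(=O)c4ccco4)CC3)nc3ccccc32)c1` differs from compound 1 by furan-2-yl in place of 4-nitrophenyl on a carbonyl carbon. Within the data shown here, no measured step touches the carbonyl substituent, so the single known step does not bear on this change, and the higher numbers of compound 2 and compound 3 cannot be separated from their different nitrogen chains. For compound 4 the expectation is therefore a small rise, a number 10.7 percentage points higher from compound 1 to compound 4 (beyond the scatter), with wide uncertainty; compound 4 is estimated at 35%, between 15% and 60%.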

Compound 4, a percentage reported as inhibition, at one concentration (the size of the read-out at that concentration, not a potency): 73.2%
Compound 4: middle estimate off by 38.2 percentage points, on the low side; the whole stated range lies below it.
By their numbers in this assay, from the lowest: compound 1; then compound 3; then compounds 2 and 4 (each within the scatter of the next).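

In this assay the substituent on the carbonyl carbon carries a large effect: furan-2-yl in place of 4-nitrophenyl gives a number 48.9 percentage points higher from compound 1 to compound 4 (beyond the scatter) with the rest of the molecule unchanged. The chain on the aromatic nitrogen of compound 1 does not by itself hold the number down, since compound 4 keeps that chain. No measurement at hand accounts for the size of this step. Open, from the compounds shown here alone, is whether a plain phenyl on the carbonyl carbon would sit with compound 1 or with compound 4, which would separate losing the nitro group from gaining the furan ring.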